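A Fluorine on the Anilino Ring of Compound 2

The source may report more compounds than this note shows. Statements on the series, on what has been measured and on what is new or still open speak of the compounds shown alone.

Of the compounds shown here, two on the shared core have been measured in an assay on isolated protein for inhibition of N-lysine methyltransferase SMYD2 (Homo sapiens), read by filter binding, with a stated time of 1 h; on this read-out higher numbers stand for weaker inhibition and lower numbers for stronger inhibition. Compound 1 `CC(C)N1C(=O)C(Cc2cc(C(F)(F)F)cc(C(F)(F)F)c2)COC12C=CC(=O)C=C2` gives 2390 nM in this assay. Compound 2 `CN1C(=O)C(CCNc2ccccc2)COC12C=CC(=O)C=C2` reports only a limit of > 20000 nM in this assay, so no number is known for it. Compound 2 therefore stands at the limit of > 20000 nM in this assay, at which 1 of the 2 values shown sits, and its distance from compound 1 cannot be stated beyond the fact that one value is a number and the other a limit.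

Compound 3 `CN1C(=O)C(CCNc2ccc(F)cc2)COC12C=CC(=O)C=C2` is the next step from compound 2. The change is fluoro in place of hydrogen on an aromatic carbon; cut one bond further out it reads anilino to (4-fluorophenyl)amino. For the measured compounds named here, no measured pair shows what such a change does in this assay. A single fluorine on that ring is expected to shift this assay by no more than the scatter, so compound 3 is expected to remain near the limit. The estimate for compound 3 is 25000 nM, with a range from 8000 nM to 60000 nM. That estimate implies a step that the limit leaves unreadable from compound 2 to compound 3, expected to stay within the scatter, and most likely another limit rather than a number.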

Compound 3, half-maximal inhibitory concentration: 11600 nM
Compound 3: the middle estimate sits 2.2-fold (0.33 log units) above what was measured; the range from low to high includes it.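

With the fluoro on the aromatic carbon, para to a large group, compound 3 gives 11600 nM in this assay, so an anilino-type side chain on the shared core now has a number. The step is an at least 1.7-fold lower number from compound 2 to compound 3 (0.23 log units; that floor lies within the scatter), and as that is only a floor, the data show that the true step is no smaller than this but not whether it lies within the scatter or beyond it. The upper end of the step cannot be read because the value for compound 2 is a limit and not a number: the limit of > 20000 nM in this assay, at which 1 of the 3 values shown sits.

The compounds shown leave open whether the fluoro itself matters or whether any other small substituent at the same place, such as a chloro or a methoxy group, would give a similar reading in this assay. They also leave open what a longer chain carrying the (4-fluorophenyl)amino group, or a methyl group on its amine nitrogen, would do to the number that compound 3 has now set for this side chain.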